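A few compounds are considered here, and "the series" means these few. Any claim that something is new, unique, unknown or untested is made for them only; others in the source may bear on it.

Compound 1 `CN(C)CCn1cnnc1-c1cc(Oc2ccc(NC(=O)N/N=C/c3ccccc3)cc2F)ccn1` carries a phenyl on the carbon with a double bond to nitrogen, and in a functional assay on U-87MG ATCC cells (Homo sapiens) for cytotoxicity, read by MTT assay, with a stated time of 72 h (on this read-out lower numbers stand for stronger inhibition and higher numbers for weaker inhibition), compound 1 gives 2250 nM. Compound 2 `CN(C)CCn1cnnc1-c1cc(Oc2ccc(NC(=O)N/N=C/c3ccc(O)c(O)c3)cc2F)ccn1` reaches only the limit of this assay, > 100000 nM. Compound 3 `CN(C)CCn1cnnc1-c1cc(Oc2ccc(NC(=O)N/N=C/c3cc(Br)c(O)c(Br)c3)cc2F)ccn1` likewise stops at the limit, > 100000 nM. Compound 1 thus holds the only number shown, the other two values being limits. Compound 4 `CN(C)CCn1cnnc1-c1cc(Oc2ccc(NC(=O)N/N=C/c3ccc(O)c(F)c3)cc2F)ccn1` differs from compound 1 by 3-fluoro-4-hydroxyphenyl in place of phenyl on a carbon with a double bond to nitrogen. The measured steps nearest to this change are an at least 44-fold higher number from compound 1 to compound 2 (1.64 log units; beyond the scatter) and an at least 44-fold higher number from compound 1 to compound 3 (1.64 log units; beyond the scatter), both large, and both sitting at the limit of > 100000 nM in this assay, at which 2 of the 3 values shown sit. The 3-fluoro-4-hydroxyphenyl entering in place of phenyl therefore points the expectation toward a large rise in this assay. Compound 4 is expected to give about 60000 nM, with a likely range from 10000 nM to 200000 nM, an expected step of a 27-fold higher number from compound 1 to compound 4 (1.43 log units; beyond the scatter).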

Compound 4, half-maximal inhibitory concentration: > 100000 nM
Compound 4: a limit, no number (the forecaster's own chance of this, stated with the estimate: 55%); middle value at least 1.6-fold (0.22 log units) away from the limit.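

The 3-fluoro-4-hydroxyphenyl group on the carbon with a double bond to nitrogen gives an at least 44-fold higher number from compound 1 to compound 4 (1.64 log units; beyond the scatter) in this assay, so pairing one hydroxy with fluoro, rather than with a second hydroxy or two bromines, still leaves no number. All three hydroxy-bearing phenyl groups shown now end at a limit of the assay: the limit of > 100000 nM in this assay, at which 3 of the 4 values shown sit. The steps among compound 2, compound 3 and compound 4 cannot be read, and these three cannot be ranked.

The compounds shown leave open whether a phenyl carrying fluoro alone, methoxy or an amine would keep a measurable value in this assay.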